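The source may report more compounds than this note shows. Statements on the series, on what has been measured and on what is new or still open speak of the compounds shown alone.

Working notes on the series. The set is followed in a functional assay on CHO cells for agonist activity at Melanocyte-stimulating hormone receptor (Homo sapiens), read by a luciferase reporter, with a stated time of 4 h; a lower number here means that less compound is needed, a higher number that more compound is needed for the effect. Compound 1 `COc1ccc(N(C(=O)CN2C=CN(c3ccccc3)C(=O)[C@@H](Cc3n[nH]c4ccccc34)C2=O)C(C)C)cc1` gives 1550 nM in this assay and stands highest among the three measured numbers. Compound 2 `COc1ccc(N(C(=O)CN2C=CN(Cc3ccccc3)C(=O)C(Cc3n[nH]c4ccccc34)C2=O)C(C)C)cc1` gives 794 nM in this assay, which is within the scatter of the value of compound 1. Compound 3 `CC(C)N(C(=O)CN1C=CN(c2ccccc2)C(=O)C(Cc2n[nH]c3ccccc23)C1=O)c1ccc(F)cc1` gives 50.1 nM in this assay, a gap to compound 1 that lies beyond the scatter. Going by the values given here, no pair among the measured compounds differs in one place only, so no single-change step is available to lean on.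

The step of interest is from compound 1 to compound 4 `COc1ccc(N(C(=O)CN2C=CN(c3ccccc3)C(=O)C(Cc3n[nH]c4ccccc34)C2=O)C(C)C)cc1`, which is still to be measured in this assay. The structural difference is the two compounds have the same atoms and bonds; at least one stereo element is drawn with a configuration in one of them and without one in the other: 1 of 1 stereo elements differ; a stereocentre at a saturated ring carbon is drawn S in compound 1 and without a configuration in compound 4; in words, the two compounds have the same atoms and bonds; at least one stereo element is drawn with a configuration in one of them and without one in the other: 1 of 1 stereo elements differ; a stereocentre at a saturated ring carbon is drawn S in compound 1 and without a configuration in compound 4.

With no measured step of this kind in hand, the expectation is a step no larger than the scatter, with a lean towards a lower number for compound 4, because compound 1 at 1550 nM is the highest value in the set while both compounds drawn without configuration sit lower. The expected step is a 1.9-fold lower number from compound 1 to compound 4 (0.29 log units; within the scatter). Compound 4 is estimated at 800 nM in this assay, within a range from 250 nM to 3000 nM.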

Compound 4, half-maximal effective concentration: 29.5 nM
Estimate against measurement, compound 4: 27-fold (1.43 log units) above, and the stated range ends above it.
By their numbers in this assay, from the lowest: compounds 4 and 3 (each within the scatter of the next); then compounds 2 and 1 (each within the scatter of the next).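

In this assay the stereocentre at a saturated ring carbon turns out to matter: with no atom changed there is a 53-fold lower number from compound 1 to compound 4 (1.72 log units; beyond the scatter), and the only structural feature to which this can be tied is this: the fact that one of compounds 1 and 4 is drawn with a defined configuration and the other without, at the place where they differ Among the compounds drawn without a configuration, the substituent on the ring nitrogen also counts, since phenyl in place of benzyl on an amide-type nitrogen in a ring gives a 27-fold lower number from compound 2 to compound 4 (1.43 log units; beyond the scatter), whereas methoxy in place of fluoro on an aromatic carbon gives a 1.7-fold lower number from compound 3 to compound 4 (0.23 log units; within the scatter), a step within the scatter. Compound 1 is therefore a poor guide to the compounds drawn without a configuration, and its high number cannot be set against the methoxy group.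

On these data alone, whether compound 4 holds a single form or a mixture stays open, and with it the value of the form opposite to S. Also open is how the numbers respond to an amine or a carboxylic acid in place of the methoxy or fluoro group, or to a longer chain than benzyl on the ring nitrogen.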